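Notes on the step from compound 3 to compound 4

The source may report more compounds than this note shows. Statements on the series, on what has been measured and on what is new or still open speak of the compounds shown alone.

Measured so far in a functional assay on MV4-11 cells (Homo sapiens) for antiproliferative activity, read by luminescence and CellTiter-Glo, with a stated time of 72 h; on this read-out higher numbers stand for weaker inhibition and lower numbers for stronger inhibition:
- compound 1 `CNc1cc(-c2ccc3cnn(Cc4ccc(C)cc4)c3c2)cn(C)c1=O` gives 3280 nM
- compound 2 `CNc1cc(-c2ccc3cnn(Cc4cc(OC)cc(OC)c4)c3c2)cn(C)c1=O` gives 190 nM
- compound 3 `CNc1cc(-c2ccc3cnn(Cc4ccc(C(F)(F)F)cc4)c3c2)cn(C)c1=O` gives 4370 nM

Compound 3 shares the high end of these numbers with compound 1, as a 1.3-fold higher number from compound 1 to compound 3 (0.12 log units; within the scatter) shows, and stands well apart from compound 2, as a 23-fold higher number from compound 2 to compound 3 (1.36 log units; beyond the scatter) shows. The change to compound 4 `CCOC(=O)Cn1ncc2ccc(-c3cc(NC)c(=O)n(C)c3)cc21` puts ethoxycarbonyl in place of 4-(trifluoromethyl)phenyl on a saturated chain carbon bound to an aromatic nitrogen, counted as ethoxycarbonyl in place of 4-(trifluoromethyl)phenyl on a saturated chain carbon bound to an aromatic nitrogen in full. All three measured steps alter the aryl group on that carbon. The two large ones, a 17-fold lower number from compound 1 to compound 2 (1.24 log units; beyond the scatter) and a 23-fold higher number from compound 2 to compound 3 (1.36 log units; beyond the scatter) again, both turn on 3,5-dimethoxyphenyl, which compound 4 does not carry. Within the data shown here, no measured compound has a group without a ring at this place, so the evidence is thin and the range is kept wide. In this assay no large fall is expected, and a small rise is the likelier direction. The estimated step is a 1.4-fold higher number from compound 3 to compound 4 (0.14 log units; within the scatter) and no more than that is expected. The expected value for compound 4 is 6000 nM within an estimated range of 1800 nM to 20000 nM.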

Compound 4, half-maximal inhibitory concentration: 8770 nM
Estimate against measurement, compound 4: 1.5-fold (0.16 log units) below; the range from low to high includes it.
By their numbers in this assay, from the lowest: compound 2; then compounds 1, 3 and 4 (each within the scatter of the next, the first and the last beyond it).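

Working from this assay, ethoxycarbonyl is the first group without a ring on a saturated chain carbon bound to an aromatic nitrogen, and a 2.0-fold higher number from compound 3 to compound 4 (0.30 log units; within the scatter) shows that removing 4-(trifluoromethyl)phenyl and its aromatic ring of carbon in favour of this smaller group does not separate compound 4 from compound 3 in this series. Among these compounds, the same exchange gives a 2.7-fold higher number from compound 1 to compound 4 (0.43 log units; beyond the scatter) against 4-methylphenyl, a modest step, while a 46-fold higher number from compound 2 to compound 4 (1.66 log units; beyond the scatter) against 3,5-dimethoxyphenyl is large, so compound 2 is now the only compound here with a large step to each of the others, and an aromatic ring at this place gives no such low number without the two methoxy groups of compound 2. No measurement on these compounds accounts for any of these differences.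

On these data alone, whether a single methoxy on the phenyl ring keeps part of what 3,5-dimethoxyphenyl gives remains open, and so does the reading for an unsubstituted benzyl group. Equally open, as far as these compounds go, is whether a carboxylic acid, a primary amide or a longer alkyl chain in place of ethoxycarbonyl would read as compound 4 does.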